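The compounds below may be only part of what the source reports. "The series", "measured", "known", "first", "only" and "open" are said of these compounds alone.

Measured compounds:
- compound 2, `Cc1cc(O)cc(C)c1-c1cccc(COc2ccc(OCC(=O)O)c(F)c2)c1`: 110 nM
- compound 3, `COc1cc(C)c(-c2cccc(COc3ccc(OCC(=O)O)c(F)c3)c2)c(C)c1`: 49.7 nM
- compound 1, `COCCCOc1cc(C)c(-c2cccc(COc3ccc(OCC(=O)O)c(F)c3)c2)c(C)c1`: "not determined" (no result reported)

All of these share one core, and they differ only in the group attached to an oxygen on one of the aromatic rings. In a functional assay on CHO cells for agonist activity at Free fatty acid receptor 1 (Homo sapiens), read by FLIPR and calcium flux (a higher number here means that more compound is needed for the effect, a lower number that less compound is needed), compound 2 gives 110 nM, while compound 3 gives 49.7 nM. Compound 3 thus shows the lowest of the two numbers available; its nearest neighbour is compound 2, and the step of a 2.2-fold lower number from compound 2 to compound 3 (0.35 log units; beyond the scatter) lies beyond the usual scatter, though it is modest in size. For compound 1 no result was reported, so it cannot be placed.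

Compound 4, `CCCOc1cc(C)c(-c2cccc(COc3ccc(OCC(=O)O)c(F)c3)c2)c(C)c1`, is not yet measured. It differs from compound 3 by ethyl in place of hydrogen on a saturated chain carbon bound to an oxygen on an aromatic ring. Among the compounds with values here, the only measured step that bears on this is a 2.2-fold lower number from compound 2 to compound 3 (0.35 log units; beyond the scatter), which also added carbon at this oxygen and lowered the number modestly. Lengthening the chain further is expected to give at most a small further drop, or none beyond the scatter, so the expected step of a 1.4-fold lower number from compound 3 to compound 4 (0.15 log units; within the scatter) is small. Compound 4 is therefore estimated at 35 nM, with a range from 12 nM to 110 nM.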

Compound 4, half-maximal effective concentration: 106 nM
Compound 4: middle estimate off by 3.0-fold (0.48 log units), on the low side; low and high end bracket the measured number.
By their numbers in this assay, from the lowest: compound 3; then compounds 4 and 2 (each within the scatter of the next).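

At this oxygen, the number in this assay does not keep falling as the chain grows: methyl lowered it, but going on from methoxy to propoxy raises it again (a 2.1-fold higher number from compound 3 to compound 4 (0.33 log units; beyond the scatter)). Compared with hydrogen on the same oxygen, the propyl group brings no change that can be told from the scatter (a 1.0-fold lower number from compound 2 to compound 4 (0.02 log units; within the scatter)), so among compound 2, compound 3 and compound 4 only the methyl group stands out, a pattern that rests on these three compounds alone. Nothing measured here accounts for this rise in the number with the longer chain.

An ethyl group on this oxygen, with a chain length between methyl and propyl, would show whether the number climbs gradually or jumps once the chain passes methyl. Compound 1 has no reported result, so it remains open how a chain carrying a further oxygen behaves here, and a chain ending in an amine or a carboxylic acid is equally untested among the compounds shown.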